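The compounds below may be only part of what the source reports. "The series", "measured", "known", "first", "only" and "open" are said of these compounds alone.

Measured in a functional assay on A549 cells (Homo sapiens) for inhibition, read by MTT assay, with a stated time of 72 h; a higher number here means a weaker inhibitor, a lower number a stronger inhibitor:
- compound 1 `Nc1ccccc1NC(=O)c1ccc(CNCc2nc(-c3ccc(Cl)cc3)no2)cc1`: 13500 nM
- compound 2 `O=C(NO)c1ccc(CNCc2nc(-c3ccc(C(F)(F)F)cc3)no2)cc1`: > 100000 nM

Compound 1 has a true number, while compound 2 has only a limit. In this assay compound 2 gives > 100000 nM, and this is a limit of the assay, not a measured number. Its true position is therefore unknown, and the limit of > 100000 nM in this assay, at which 1 of the 2 values shown sits, is all that can be said of it.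

The next compound to be measured is compound 3 `O=C(NO)c1ccc(CNCc2nc(-c3ccc(Cl)cc3)no2)cc1`. It differs from compound 2 in one place: chloro in place of trifluoromethyl on an aromatic carbon. Compound 3 thus carries chloro where compound 2 carries trifluoromethyl, para to a large group.

For the measured compounds named here, no measured pair shows what this swap does, so the expectation is cautious. It starts from compound 2 at > 100000 nM, and a change beyond the usual scatter is not expected in this assay. The estimate is an at least 1.4-fold lower number from compound 2 to compound 3 (0.15 log units; that floor lies within the scatter), an expected step that is small and slightly towards a stronger inhibitor. Compound 3 is expected at about 70000 nM, with an estimated range of 20000 nM to 150000 nM.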

Compound 3, half-maximal inhibitory concentration: > 100000 nM
Compound 3: no number, only a limit; the forecaster's own chance of this, stated with the estimate: 50%; middle value at least 1.4-fold (0.15 log units) away from the limit.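

In this assay compound 3 gives > 100000 nM, and this is a limit of the assay, not a number. Compound 2 and compound 3 both stand at such a limit, so the swap of trifluoromethyl for chloro on the aromatic carbon cannot be read in either direction, and nothing can be said of its size: the limit of > 100000 nM in this assay, at which 2 of the 3 values shown sit.

What the result does add lies at the other end of the molecule, where chloro is the same in both compounds and only the group on the amide-type nitrogen changes: hydroxy in place of 2-aminophenyl gives an at least 7.4-fold higher number from compound 1 to compound 3 (0.86 log units; beyond the scatter), a step beyond the scatter that makes compound 1 the stronger inhibitor of this pair.

On these data alone, it remains open whether any other group at this ring position, such as a methoxy group or an amine, would bring a compound with hydroxy on the nitrogen to a true number. As far as these compounds go, it is equally open how the amide-type nitrogen would respond to a group other than these two, such as a plain phenyl ring or a longer chain, with chloro kept in place.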